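The compounds below may be only part of what the source reports. "The series", "measured", "known", "first", "only" and "open" are said of these compounds alone.

In a functional assay on WM 266-4 cells (Homo sapiens) for antiproliferative activity, read by MTT assay, with a stated time of 24 h (a higher number here means a weaker inhibitor of growth, a lower number a stronger inhibitor of growth), two compounds sharing one core have been measured so far. Compound 1 `Ic1ccc(C2CC(c3ccc4c(c3)OCCO4)=NN2c2ccccc2)cc1`, with 4-iodophenyl on a saturated ring carbon, gives 3470 nM, a real number to work from. Compound 2 `c1ccc(N2N=C(c3ccc4c(c3)OCCO4)CC2c2cccc3ccccc23)cc1`, with naphthalen-1-yl at that place, gives only a limit, > 100000 nM.

Compound 3 `c1ccc(C2CC(c3ccc4c(c3)OCCO4)=NN2c2ccccc2)cc1` has not yet been measured. It has phenyl in place of naphthalen-1-yl on a saturated ring carbon, the same carbon that changed before: phenyl in place of naphthalen-1-yl on a saturated ring carbon.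

Within the data shown here, one measured step bears on this change: an at least 28-fold higher number from compound 1 to compound 2 (1.45 log units; beyond the scatter), which is large and lies beyond the scatter. It brought naphthalen-1-yl in, and compound 3 takes that group out again. A large step towards a lower number, meaning a stronger inhibitor of growth, is therefore expected in this assay. Its size stays loose, as the starting point is a limit and a single step is thin evidence.

The expected step is an at least 8.3-fold lower number from compound 2 to compound 3 (0.92 log units; beyond the scatter). For compound 3 the estimated value is 12000 nM, with an expected range from 3000 nM to 50000 nM.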

Compound 3, concentration for 50% growth inhibition: 22400 nM
Beside the measured number, compound 3's estimate is 1.9-fold (0.27 log units) below it, and the stated range covers the measured number.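

Replacing naphthalen-1-yl with phenyl gives an at least 4.4-fold lower number from compound 2 to compound 3 (0.64 log units; beyond the scatter) in this assay, so the group on this saturated ring carbon decides whether growth inhibition reaches a measurable number in this series. Hydrogen in place of iodo on an aromatic carbon gives a 6.5-fold higher number from compound 1 to compound 3 (0.81 log units; beyond the scatter), which shows that a change on the phenyl ring itself, and not only a swap of the whole group, moves the number beyond the scatter, and it leaves compound 1 as the strongest inhibitor of growth among the three. Compound 2 has only a limit, so the step that leaves it gives a floor and not a true size: the limit of > 100000 nM in this assay, at which 1 of the 3 values shown sits.

The compounds shown compare only iodo and hydrogen on this phenyl ring, so it remains open whether the gain is special to iodine or would also appear with chloro, bromo or a methoxy group. Also open, as far as these compounds go, is how a phenyl ring carrying an amine or a carboxylic acid would behave at this carbon, and whether a non-aromatic group such as cyclohexyl would keep any activity at all.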